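The compounds below may be only part of what the source reports. "The series", "measured", "known", "first", "only" and "open" are said of these compounds alone.

Compound 1 `O=C(NO)c1ccc(CN2C(=O)/C(=C3\Nc4ccccc4\C3=N/O)c3cc(Cl)ccc32)cc1`: 60 nM
Compound 2 `O=C(/C=C/c1ccc(CN2C(=O)/C(=C3\Nc4ccccc4\C3=N/O)c3cc(Br)ccc32)cc1)NO`: 60 nM

Both compounds were tested in a functional assay on SW-620 cells (Homo sapiens) for cytotoxicity, read by colorimetric assay; on this read-out lower numbers stand for stronger inhibition and higher numbers for weaker inhibition. Compound 2 stands level with compound 1, and the gap between them lies within the normal scatter of repeated measurements. The two structures differ in more than one place, so this comparison does not isolate any single change.

Compound 3 `O=C(NO)c1ccc(CN2C(=O)/C(=C3\Nc4ccccc4\C3=N/O)c3cc(Br)ccc32)cc1` has not yet been measured. It comes from compound 2 by one change: hydroxycarbamoyl in place of 2-(hydroxycarbamoyl)ethenyl on an aromatic carbon. Compound 3 thus carries the hydroxycarbamoyl group also found in compound 1, which gives 60 nM. Among the measured compounds shown here, no measured pair shows this change alone, so the expectation rests on that single reading. A step beyond the scatter in this assay is not expected, in either direction. The expected size is no change at the digits printed from compound 2 to compound 3 (within the scatter). For compound 3 the estimated value is 60 nM, with an expected range of 25 nM to 150 nM.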

Compound 3, half-maximal inhibitory concentration: 70 nM
Compound 3: the middle estimate sits 1.2-fold (0.07 log units) below what was measured; measured number inside the range.
By their numbers in this assay, from the lowest: compounds 1, 2 and 3 (each within the scatter of the next).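

Replacing 2-(hydroxycarbamoyl)ethenyl with hydroxycarbamoyl on this aromatic carbon, para to a large group, gives a 1.2-fold higher number from compound 2 to compound 3 (0.07 log units; within the scatter) in this assay and so shows that, with bromo on the core, the shorter group reads the same as the longer one within the scatter. Now that the hydroxycarbamoyl group is held constant, bromo in place of chloro can also be read alone, and it gives a 1.2-fold higher number from compound 1 to compound 3 (0.07 log units; within the scatter) as a second step that the assay cannot tell from no change. No available evidence bears on the reason for either result.

As far as these compounds go, whether this position would accept a carboxylic acid or a primary amide in place of hydroxycarbamoyl remains open, as does the effect of a longer chain ending in hydroxycarbamoyl. A fluoro or methoxy group in place of the bromo or chloro also remains to be read.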